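Phenol in place of bromine on the benzyl arm

A few compounds are considered here, and "the series" means these few. Any claim that something is new, unique, unknown or untested is made for them only; others in the source may bear on it.

Of the compounds shown here, three sharing one core have been measured in a functional assay on G-361 cells (Homo sapiens) for inhibition, with a stated time of 72 h; on this read-out lower numbers stand for stronger inhibition and higher numbers for weaker inhibition. Compound 1, `NC1CCC(Nc2nc(NCc3ccc(Br)cc3)c3ncn(C4CCCC4)c3n2)CC1`, gives 1480 nM and stands highest of the three numbers, that is, weakest. Compound 2, `NC1CCC(Nc2nc(NCc3ccc(-c4cccc(F)c4)nc3)c3ncn(C4CCCC4)c3n2)CC1`, gives 49 nM, and compound 3, `NC1CCC(Nc2nc(NCc3ccc(-c4ccccc4O)nc3)c3ncn(C4CCCC4)c3n2)CC1`, gives 24 nM. Within the data shown here, the only single-point step among the measured compounds is a 2.0-fold lower number from compound 2 to compound 3 (0.31 log units; beyond the scatter), a hydroxyl brought onto an aromatic ring.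

Compound 4, `NC1CCC(Nc2nc(NCc3cc(Cl)ccc3O)c3ncn(C4CCCC4)c3n2)CC1`, is made from compound 1 by the change (5-chloro-2-hydroxyphenyl in place of 4-bromophenyl on a saturated chain carbon bound to a nitrogen on an aromatic ring). Among the measured compounds shown here, no measured pair reproduces this exact change, since compound 4 carries its hydroxyl on the ring joined to the saturated chain carbon rather than on a further ring. The step from compound 2 to compound 3 bears on it only loosely, showing that a hydroxyl on an aromatic carbon in this series can bring a modest gain; the hydroxyphenyl compound 3 also holds the lowest number of the three. He therefore expects in this assay a modest step to a lower number for compound 4, a 3.0-fold lower number from compound 1 to compound 4 (0.47 log units; beyond the scatter), without approaching the level of compound 3. His estimate for compound 4 is 500 nM, in the range 150 nM to 1600 nM.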

Compound 4, half-maximal inhibitory concentration: 390 nM
The estimate for compound 4 lay 1.3-fold (0.11 log units) above the measured number; low and high end bracket the measured number.
By their numbers in this assay, from the lowest: compound 3; then compound 2; then compound 4; then compound 1.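

The result shows that the saturated chain carbon bound to a nitrogen on an aromatic ring can carry 5-chloro-2-hydroxyphenyl in place of 4-bromophenyl, and that in this assay this exchange gives a 3.8-fold lower number from compound 1 to compound 4 (0.58 log units; beyond the scatter) on the shared core. Among these compounds, the earlier single-place step concerned a further ring on a longer arm, so this is the first step read directly on the ring joined to the saturated chain carbon, and there a bromine leaves while a chlorine and a hydroxyl enter. The two new groups arrive together, so the step cannot be divided between them, and nothing measured here bears on why the number moved.

As far as these compounds go, it remains open how much of the step belongs to the hydroxyl and how much to the chlorine, which a 2-hydroxybenzyl arm without the halogen, or a methoxy group in place of the hydroxyl, could separate. From the compounds shown here alone, it also remains open how an amine or a carboxylic acid on this same ring would read in this assay.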